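Swapping the Aryl Group: From Compound 2 to Compound 3

The compounds below may be only part of what the source reports. "The series", "measured", "known", "first", "only" and "open" are said of these compounds alone.

Among the compounds with values here, compound 2 `CCOC(=O)c1cnn(-c2nc(-c3cccc(O)c3O)c(C#N)c(=O)n2C)c1N` gives 53 ug/mL in a functional assay, with a stated time of 10 min (on this read-out lower numbers stand for stronger inhibition and higher numbers for weaker inhibition), the lowest of the two numbers known so far, though compound 1 `CCOC(=O)c1cnn(-c2nc(-c3ccc(OC)cc3)c(C#N)c(=O)n2C)c1N` sits within the scatter of it at 74 ug/mL. Compound 3 `CCOC(=O)c1cnn(-c2nc(-c3ccc(Cl)cc3)c(C#N)c(=O)n2C)c1N` carries 4-chlorophenyl in place of 2,3-dihydroxyphenyl on an aromatic carbon. Within the data shown here, the only measured step that bears on this change, a 1.4-fold lower number from compound 1 to compound 2 (0.14 log units; within the scatter), also exchanged the aryl group and stayed within the scatter. Compound 3 is therefore expected to show no step beyond the scatter in this assay, a 1.1-fold higher number from compound 2 to compound 3 (0.05 log units; within the scatter). The estimate for compound 3 is 60 ug/mL, with a range from 25 ug/mL to 150 ug/mL.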

Compound 3, half-maximal inhibitory concentration: 94 ug/mL
Estimate against measurement, compound 3: 1.6-fold (0.19 log units) below, within the range that was stated.
By their numbers in this assay, from the lowest: compounds 2, 1 and 3 (each within the scatter of the next).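

With this assay, taking out the 2,3-dihydroxyphenyl group, with its 2 hydrogen-bond donors, and putting in 4-chlorophenyl, with 0, stays within the scatter (a 1.8-fold higher number from compound 2 to compound 3 (0.25 log units; within the scatter)). Chloro in place of methoxy also stays within it (a 1.3-fold higher number from compound 1 to compound 3 (0.10 log units; within the scatter)), so all three aryl groups at this position read alike, and hydrogen-bond donors on the ring are not needed to hold this level of inhibition. No available data bear on the reason for this.

The compounds shown leave open whether any change at this position can move the number beyond the scatter. An amine or a carboxylic acid on the phenyl ring, or a longer chain in its place, would be a sharper test.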